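Stretching the Chain a Little Further

A few compounds are considered here, and "the series" means these few. Any claim that something is new, unique, unknown or untested is made for them only; others in the source may bear on it.

In a functional assay on cells (Homo sapiens) for antiproliferative activity, read by sulforhodamine B assay, with a stated time of 48 h (a higher number here means a weaker inhibitor, a lower number a stronger inhibitor), compound 1 (`CCCCCCCCCCNC(=O)[C@@H]1CSC(c2cc(OC)c(OC)c(OC)c2)N1`) reads 14500 nM while compound 2 (`CCCCCCCCCCCCCCNC(=O)[C@@H]1CSC(c2cc(OC)c(OC)c(OC)c2)N1`) reads 2000 nM and so holds the lower of the two numbers, which marks the stronger inhibitor of the pair. Compound 3 (`CCCCCCCCCCCCCCCCNC(=O)[C@@H]1CSC(c2cc(OC)c(OC)c(OC)c2)N1`) has not been measured yet. The change ethyl in place of hydrogen on a saturated chain carbon, ten or more bonds along the chain from an amide-type nitrogen puts ethyl in place of hydrogen on a saturated chain carbon, ten or more bonds along the chain from an amide-type nitrogen. For the measured compounds named here, only one measured step bears on this: butyl entering at the same kind of place gave a 7.3-fold lower number from compound 1 to compound 2 (0.86 log units; beyond the scatter) and lowered the number. Ethyl is the smaller addition, and a single step cannot show whether the fall continues. What is expected in this assay is a smaller fall, an estimated 2.0-fold lower number from compound 2 to compound 3 (0.30 log units; within the scatter) that may not clear the usual scatter. For compound 3 the estimated value is 1000 nM with 400 nM to 2500 nM as the expected range.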

Compound 3, half-maximal inhibitory concentration: 1800 nM
The estimate for compound 3 lay 1.8-fold (0.26 log units) below the measured number; measured number inside the range.
By their numbers in this assay, from the lowest: compounds 3 and 2 (each within the scatter of the next); then compound 1.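

In this assay the ethyl addition gives a 1.1-fold lower number from compound 2 to compound 3 (0.05 log units; within the scatter) and stays within the usual scatter, so compound 2 and compound 3 cannot be told apart, and the clear fall seen with butyl at this kind of place does not carry on here. Taken across the whole set, the change gives an 8.1-fold lower number from compound 1 to compound 3 (0.91 log units; beyond the scatter) and that step lies beyond the scatter, so among these three compounds the longer chains stand clearly apart from compound 1 but not from each other. No measurement at hand explains why the numbers for compound 2 and compound 3 sit so close. A still longer chain could hold level, rise or fall. Also open, from the compounds shown here alone, is how a chain ending in an amine or a carboxylic acid would read at this place.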